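Furan-to-oxazole swap on the thienopyrimidine-free core series

The source may hold more compounds than are shown below. What is called first, only, known or untested is meant among the compounds shown, and "the series" means these compounds.

The three measured compounds share one core, varied at two places. Compound 1 `Cc1ccc(-c2nc(N)c3ccsc3n2)o1` gives in a functional assay on CHO-K1 cells for antagonist activity at adenosine receptor A1 (Homo sapiens), read by a beta-galactosidase reporter and cAMP accumulation, with stated times of 15 min and 6 h (a lower number here means a stronger inhibitor, a higher number a weaker inhibitor), a value of 493 nM. Compound 2 `COc1ccccc1Cc1cc2c(N)nc(-c3ccc(C)o3)nc2s1` gives in this assay a value of 122 nM. Compound 3 `CCc1ccc(-c2nc(N)c3cc(Cc4ccccc4)sc3n2)o1` gives in this assay a value of 223 nM, the second highest of the three numbers; its nearest neighbour is compound 2, within the scatter, and its furthest is compound 1, beyond the scatter. No two of these compounds differ in only one place, so no single step can be isolated from them.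

Compound 4 `Nc1nc(-c2cnco2)nc2sc(Cc3ccccc3)cc12` has not been measured in this assay. It differs from compound 3 by 1,3-oxazol-5-yl in place of 5-ethylfuran-2-yl on an aromatic carbon. The measured set holds no change of this kind, so the size of the step is not anchored; the change removes the ethyl-bearing furan that all three measured compounds carry. The expectation is a moderately weaker inhibitor, with the step from compound 3 to compound 4 estimated as a 2.7-fold higher number from compound 3 to compound 4 (0.43 log units; beyond the scatter). Compound 4 is therefore estimated at 600 nM, with a range from 150 nM to 2500 nM.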

Compound 4, inhibition constant: 106 nM
Beside the measured number, compound 4's estimate is 5.7-fold (0.75 log units) above it, and the stated range ends above it.
By their numbers in this assay, from the lowest: compounds 4, 2 and 3 (each within the scatter of the next, the first and the last beyond it); then compound 1.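

In this assay, for the compounds shown here, the 5-ethylfuran-2-yl group proves dispensable at this aromatic carbon between two ring nitrogen atoms: 1,3-oxazol-5-yl in its place gives a 2.1-fold lower number from compound 3 to compound 4 (0.32 log units; beyond the scatter) as the first single-place step. The earlier compounds shown here all carried a substituted furan here, so they could not show that a ring with 2 hetero atoms and 5 heavy atoms is accepted in place of one with 1 hetero atom and 7 heavy atoms, with no loss of inhibition. Nothing at hand accounts for the size or direction of this step.

Going by these compounds, the step changes the ring and removes the ethyl chain together, so their separate contributions remain open; unsubstituted furan-2-yl and an ethyl-bearing 1,3-oxazol-5-yl would separate the two. On these data alone, whether the same swap carries over to the core of compound 1 or compound 2 also remains open.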